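Methoxy to hydrogen: working notes on four compounds

The compounds below may be only part of what the source reports. "The series", "measured", "known", "first", "only" and "open" are said of these compounds alone.

Measured so far in a functional assay on KM12 cells (Homo sapiens) for inhibition, read by sulforhodamine B assay, with a stated time of 48 h; a higher number here means a weaker inhibitor of growth, a lower number a stronger inhibitor of growth:
- compound 1, `COc1cc(-c2cc(/C=C/C(=O)c3ccc(N)cc3)[nH]n2)cc(OC)c1OC`, gives 1410 nM
- compound 2, `COc1ccc(-c2cc(/C=C/C(=O)c3ccc(N)cc3)[nH]n2)cc1OC`, gives 1680 nM
- compound 3, `COc1cc(C(=O)/C=C/c2cc(-c3cc(OC)c(OC)c(OC)c3)n[nH]2)cc(OC)c1OC`, gives 1490 nM

The three measured values lie close together; in this assay the gaps among compound 1, compound 2 and compound 3 all fall within the usual scatter, so no ordering among them is claimed.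

Within the data shown here, the one counted step is from compound 1 to compound 2: hydrogen in place of methoxy on an aromatic carbon. It gave a 1.2-fold higher number from compound 1 to compound 2 (0.08 log units; within the scatter).

Compound 4, `COc1ccc(-c2cc(/C=C/C(=O)c3cc(OC)c(OC)c(OC)c3)[nH]n2)cc1OC`, is not yet measured. It stands to compound 3 as compound 2 stands to compound 1: hydrogen in place of methoxy on an aromatic carbon. The place described for this change is the same word for word in both pairs, so it is the same change. Among the measured compounds shown here, the difference between the core of compound 1 and the core of compound 3 is not broken down here; what is known is only that compound 1 and compound 3 give values within the scatter of each other in this assay.

For the measured compounds named here, with only one prior instance of the change, and that one within the scatter, the expected step from compound 3 to compound 4 is a 1.2-fold higher number from compound 3 to compound 4 (0.08 log units; within the scatter) in this assay, resting on the earlier step of a 1.2-fold higher number from compound 1 to compound 2 (0.08 log units; within the scatter). Going by the values given here, compound 4 is therefore estimated at 1800 nM, with a range from 900 nM to 3600 nM; the range is wide because the move between cores is not broken down and the single prior step of a 1.2-fold higher number from compound 1 to compound 2 (0.08 log units; within the scatter) carries little weight on its own.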

Compound 4, concentration for 50% growth inhibition: 780 nM
Beside the measured number, compound 4's estimate is 2.3-fold (0.36 log units) above it, outside the stated range (below it).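

In this assay, hydrogen in place of methoxy on an aromatic carbon gave a 1.9-fold lower number from compound 3 to compound 4 (0.28 log units; within the scatter), so on this core, as on the core of compound 1, the step stays inside the usual scatter. Set beside each other, the two instances of the change give no ground for calling them different: the same change on two cores in this assay, a 1.2-fold higher number (0.08 log units; within the scatter) from compound 1 to compound 2 and a 1.9-fold lower number (0.28 log units; within the scatter) from compound 3 to compound 4, 2.3-fold (0.36 log units) apart, within the scatter of two such steps

This means that no dependence of the change on the core can be claimed from these four compounds, but it does not show that the change carries over from one core to the other with a fixed size or direction, nor that it does anything measurable on either core, since neither step can be told apart from repeat variation.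

What the compounds shown leave open is whether the same aromatic carbon would stay this undemanding with a group other than methoxy or hydrogen on it, such as a hydroxyl, a fluorine or a longer alkoxy chain like ethoxy. Also open, going by these compounds, is whether the pattern of small steps holds on a third core, or in any read-out other than this assay.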